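Adding a Trifluoromethyl Group to the Fluorophenyl Ring

The source may hold more compounds than are shown below. What is called first, only, known or untested is meant among the compounds shown, and "the series" means these compounds.

Compound 1 `Cc1ccccc1NC(=O)N[C@H](C)c1ccccc1` and compound 2 `C[C@@H](NC(=O)Nc1ccccc1F)c1ccccc1` have the same shared core. In an ADME assay on the whole organism with Oryza sativa as the target, tested at 0.1 uM (on this read-out higher numbers stand for a weaker effect at the one concentration tested and lower numbers for a stronger effect), compound 1 gives 100%, and compound 2 gives 97%; the step of a number 3 percentage points lower from compound 1 to compound 2 (within the scatter) lies within the scatter, so compound 2 stands alongside compound 1 rather than apart from it. Compound 3 `C[C@@H](NC(=O)Nc1cc(C(F)(F)F)ccc1F)c1ccccc1` differs from compound 2 by trifluoromethyl in place of hydrogen on an aromatic carbon. For the measured compounds named here, no measured step involves a trifluoromethyl group, and the only step known, a number 3 percentage points lower from compound 1 to compound 2 (within the scatter), stayed within the scatter. Compound 3 is therefore expected to show no change beyond the scatter, a number 2 percentage points lower from compound 2 to compound 3 (within the scatter). For compound 3 the estimate is 95%, with a range from 80% to 100%.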

Compound 3, a percentage reported as activity, at one concentration (the size of the read-out at that concentration, not a potency): 87%
Compound 3: middle estimate off by 8 percentage points, on the high side; the range from low to high includes it.
By their numbers in this assay, from the lowest: compounds 3, 2 and 1 (each within the scatter of the next, the first and the last beyond it).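

In this assay, placing trifluoromethyl in place of hydrogen on an aromatic carbon, para to a fluoro group and meta to a large group, gives a number 10 percentage points lower from compound 2 to compound 3 (within the scatter). This position can therefore take a group far larger than hydrogen without a change that stands clear of the usual scatter. No measurement available here helps to interpret this result.

On these data alone, it remains open whether an amine or a carboxylic acid at this position would move the read-out beyond the scatter. Also open, as far as these compounds go, is whether trifluoromethyl would give a similar result without the fluoro group on the ring.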